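Methylsulfanyl for Aminoamino: Expecting Compound 4

A few compounds are considered here, and "the series" means these few. Any claim that something is new, unique, unknown or untested is made for them only; others in the source may bear on it.

Compound 1 `CSc1nc(-c2cccs2)c(C#N)c(=O)n1C` gives 87 ug/mL in a functional assay, with a stated time of 150 min; on this read-out lower numbers stand for stronger inhibition and higher numbers for weaker inhibition.
Compound 2 `Cn1c(NN)nc(-c2cccs2)c(C#N)c1=O` gives 63 ug/mL in this assay.
Compound 3 `Cn1c(NN)nc(-c2ccccc2Cl)c(C#N)c1=O` gives 62 ug/mL in this assay.

Compounds 2 and 3 share the aminoamino group but differ in their cores; the difference between the two cores is not broken down here, and their two values lie within the scatter of each other. Compounds 2 and 1 differ in one place only, (methylsulfanyl in place of aminoamino on an aromatic carbon), and this gave a 1.4-fold higher number from compound 2 to compound 1 (0.14 log units; within the scatter).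

Compound 4 `CSc1nc(-c2ccccc2Cl)c(C#N)c(=O)n1C` has not yet been measured. It differs from compound 3 by the same kind of change, (methylsulfanyl in place of aminoamino on an aromatic carbon), with the surroundings differing in one respect: in compound 2 the place is meta to a thiophen-2-yl group (5 heavy atoms), whereas in compound 3 it is meta to a group of 7 heavy atoms.

Beside a 1.4-fold higher number from compound 2 to compound 1 (0.14 log units; within the scatter), the step expected for compound 4 is a 1.4-fold higher number from compound 3 to compound 4 (0.14 log units; within the scatter), resting on the value of compound 3, 62 ug/mL, in this assay. Compound 4 is therefore estimated at 85 ug/mL, with a likely range from 45 ug/mL to 165 ug/mL.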

Compound 4, half-maximal inhibitory concentration: 81 ug/mL
For compound 4 the middle estimate is 1.0-fold (0.02 log units) above the measured one; low and high end bracket the measured number.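

In this assay, methylsulfanyl in place of aminoamino gave a 1.3-fold higher number from compound 3 to compound 4 (0.12 log units; within the scatter), and this step can be set beside the one seen earlier on the other core: the same change on two cores in this assay, a 1.4-fold higher number (0.14 log units; within the scatter) from compound 2 to compound 1 and a 1.3-fold higher number (0.12 log units; within the scatter) from compound 3 to compound 4, 1.1-fold (0.02 log units) apart, within the scatter of two such steps. On these two cores, then, the change carried over with no difference that can be told from the scatter. Each step on its own also lies within the scatter, however, so the data do not show that the change moves the number at all, and two cores say nothing of how it would behave on others in the series.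

The compounds shown carry only aminoamino or methylsulfanyl at this place, which leaves open what a larger amine such as dimethylamino, or a longer sulfur-linked chain such as butylsulfanyl, would do there. Also open, as far as these compounds go, is whether replacing the cyano group with a carboxylic acid would leave the numbers within the same narrow span.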